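Chloro in place of hydrogen on compound 2's substituted benzyl ring

The source may report more compounds than this note shows. Statements on the series, on what has been measured and on what is new or still open speak of the compounds shown alone.

Compound 1 `CNC(=O)c1ccc(CN(C)C(=O)c2cc(Cl)c(O)cc2O)cc1`: 34800 nM
Compound 2 `COc1cc(CN(C)C(=O)c2cc(Cl)c(O)cc2O)cc(OC)c1OC`: 73100 nM
Compound 3 `O=C(NCc1ccccc1)c1cc(Cl)c(O)cc1O`: 86200 nM

Of the compounds shown here, three sharing the chlorinated dihydroxybenzamide core have been measured in a functional assay on NCI-H1975 cells (Homo sapiens) for antiproliferative activity, with a stated time of 72 h; a lower number here means a stronger inhibitor of growth, a higher number a weaker inhibitor of growth. Compound 2 stands second highest among the three numbers. Its nearest neighbour is compound 3, whose value lies within the scatter of compound 2, so the two cannot be told apart. Compound 1 gives a lower number than compound 2, and that gap lies beyond the scatter. All three are weak growth inhibitors.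

Compound 4 `COc1cc(CN(C)C(=O)c2cc(Cl)c(O)cc2O)c(Cl)c(OC)c1OC` has not yet been measured. Relative to compound 2 it carries chloro in place of hydrogen on an aromatic carbon. No comparison of this kind exists among the measured compounds, so the expected size of the step in this assay rests on the structural change alone. A single chloro added to an aromatic carbon of the already substituted benzyl ring is expected to shift the number only modestly, if at all, in either direction, and most likely not beyond the scatter. The estimate for compound 4 is 55000 nM, with a range from 18000 nM to 160000 nM. This estimate means a step of a 1.3-fold lower number from compound 2 to compound 4 (0.12 log units; within the scatter), expected to be small.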

Compound 4, concentration for 50% growth inhibition: 33800 nM
Compound 4: middle estimate off by 1.6-fold (0.21 log units), on the high side, within the range that was stated.
By their numbers in this assay, from the lowest: compounds 4 and 1 (each within the scatter of the next); then compounds 2 and 3 (each within the scatter of the next).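

In this assay, for the compounds shown here, the chloro in place of hydrogen gives the first step that can be read: a 2.2-fold lower number from compound 2 to compound 4 (0.34 log units; beyond the scatter). The position, on an aromatic carbon of a six-membered aromatic ring of carbon only, ortho to a large group and ortho to a methoxy group, is therefore one where a single added chlorine atom changes the number by a modest amount that is distinguishable from the scatter, even with three methoxy groups already on the ring, while compound 4, at 33800 nM, remains a weak growth inhibitor. Nothing given here accounts for the direction or the size of this step.

The compounds shown leave open whether the step belongs to chlorine itself or would also appear with another group on this carbon, such as a fluoro, a bromo, a methyl, an amine or a carboxylic acid. Going by these compounds alone, they also leave open whether the same chloro would give a similar step on a ring without the three methoxy groups, such as the one in compound 1.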